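A few compounds are considered here, and "the series" means these few. Any claim that something is new, unique, unknown or untested is made for them only; others in the source may bear on it.

Measured in a functional assay on WiDr cells (Homo sapiens) for inhibition; a higher number here means a weaker inhibitor, a lower number a stronger inhibitor:
compound 1, `CCOC(=O)c1ccc(NC(=O)N2CC2C#N)cc1`: 4200 nM
compound 2, `CC(=O)c1cccc(NC(=O)N2CC2C#N)c1`: 9000 nM
compound 3, `N#CC1CN1C(=O)Nc1ccc(C(F)(F)F)cc1`: 5800 nM

Compound 3 stands second highest of the three numbers; its nearest neighbour is compound 1 and its furthest is compound 2, both within the scatter of it. Compound 4, `N#CC1CN1C(=O)Nc1ccccc1`, differs from compound 3 by hydrogen in place of trifluoromethyl on an aromatic carbon.

Going by the values given here, the one measured step on the same aromatic carbon, a 1.4-fold higher number from compound 1 to compound 3 (0.14 log units; within the scatter), exchanged one group for another and stayed within the scatter. Among the compounds with values here, no measured step removes a group there altogether, so the bearing on compound 4 is indirect. With all three numbers close together, no shift beyond the scatter is expected, and a 1.2-fold higher number from compound 3 to compound 4 (0.08 log units; within the scatter) is estimated as the step to compound 4. Compound 4 is therefore expected near 7000 nM, in the range 2500 nM to 20000 nM.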

Compound 4, half-maximal inhibitory concentration: 12000 nM
The estimate for compound 4 lay 1.7-fold (0.23 log units) below the measured number; low and high end bracket the measured number.
By their numbers in this assay, from the lowest: compounds 1, 3, 2 and 4 (each within the scatter of the next, the first and the last beyond it).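

In this assay, removing the group outright has a measurable cost that the exchange of one group for another did not reveal: a 2.1-fold higher number from compound 3 to compound 4 (0.32 log units; beyond the scatter) and a 2.9-fold higher number from compound 1 to compound 4 (0.46 log units; beyond the scatter) both lie beyond the scatter, though both are modest. Trifluoromethyl and ethoxycarbonyl therefore each go with a lower number than hydrogen on the aromatic carbon. Compound 2 goes against this pattern, since a 1.3-fold higher number from compound 2 to compound 4 (0.12 log units; within the scatter) stays within the scatter for acetyl.

No supporting data bear on the origin of these steps. Going by these compounds, whether an amine, a carboxylic acid or a longer chain on this carbon would keep the lower number remains open.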